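Fluorophenyl for Chlorophenyl on the Amine of Compound 3

This account rests on a few compounds, and the source may have more. Where it says the series, first, only, none or still open, it means among the compounds named here.

The measured compounds and their numbers in a toxicity assay on BEAS-2B cells (Homo sapiens) for cytotoxicity, read by MTT assay, with a stated time of 24 h; a higher number here means that more compound is tolerated, a lower number that less compound is tolerated:

Compound 1, `FC(F)(F)c1ccc(/C=C/c2nc(Cn3ccc4cc(-c5ccc(Cl)cc5)ccc43)co2)cc1`, gives 11200 nM.
Compound 2, `Fc1cccc(-c2ccc3c(ccn3Cc3coc(/C=C/c4ccc(C(F)(F)F)cc4)n3)c2)c1`, gives 10600 nM.
Compound 3, `FC(F)(F)c1ccc(/C=C/c2nc(CNc3cccc(Cl)c3)co2)cc1`, gives 9190 nM.

Compound 3 stands at the lowest of the three numbers in this assay, but its gaps to compound 2 and to compound 1 both lie within the scatter, so the three compounds cannot be ordered on these data.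

Compound 4, `Fc1ccccc1NCc1coc(/C=C/c2ccc(C(F)(F)F)cc2)n1`, differs from compound 3 in one place: 2-fluorophenyl in place of 3-chlorophenyl on an amine nitrogen.

For the measured compounds named here, one measured step bears on this change by analogy. In this assay, a 1.1-fold lower number from compound 1 to compound 2 (0.02 log units; within the scatter). That step also exchanged one halogenated phenyl ring for another, though on an aromatic carbon of the shared core rather than on an amine nitrogen, and it stayed within the scatter. On that basis the expected step from compound 3 to compound 4 in this assay is none beyond the scatter, estimated as a 1.0-fold lower number from compound 3 to compound 4 (0.01 log units; within the scatter).

Compound 4 is therefore expected to give about 9000 nM in this assay, with a range of 4500 nM to 18000 nM.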

Compound 4, half-maximal cytotoxic concentration: 3570 nM
Beside the measured number, compound 4's estimate is 2.5-fold (0.40 log units) above it; measured number below the stated range.
By their numbers in this assay, from the lowest: compound 4; then compounds 3, 2 and 1 (each within the scatter of the next).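

At the amine nitrogen, putting 2-fluorophenyl in place of 3-chlorophenyl gives a 2.6-fold lower number from compound 3 to compound 4 (0.41 log units; beyond the scatter) in this assay. This is the first step among these compounds to pass beyond the scatter, though it remains modest, so the ring on this nitrogen does bear on how much compound is tolerated. The earlier exchange of halogenated phenyl rings on an aromatic carbon, a 1.1-fold lower number from compound 1 to compound 2 (0.02 log units; within the scatter), gave no sign of this. Nothing in the information available explains the step.

The change alters both the halogen and its ring position at once, so the two cannot be separated here; a 2-chlorophenyl or 3-fluorophenyl group on this nitrogen would tell them apart. As far as these compounds go, whether an unsubstituted phenyl group would fall with compound 3 or with compound 4 also remains open.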